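Thiophen-2-yl for furan-2-yl in a small series

A few compounds are considered here, and "the series" means these few. Any claim that something is new, unique, unknown or untested is made for them only; others in the source may bear on it.

Compound 1 `CC(C)OC(=O)C1=C(C(F)(F)F)NC(=O)NC1c1ccco1` carries an isopropoxycarbonyl group and a trifluoromethyl group on its core, while compound 3 `CC1=C(C(=O)OCC(F)(F)F)C(c2ccco2)NC(=O)N1` and compound 2 `CC1=C(C(=O)OCC(F)(F)F)C(c2cccs2)NC(=O)N1` share a different core that bears a methyl group. The difference between the two cores is not broken down here. In an assay on HeLa cells for displacement of a labelled ligand from adenosine receptor A3 (Homo sapiens), read by radioligand binding, with a stated time of 180 min, tested at 1 uM (a lower number here means less inhibition, a higher number more inhibition at the concentration tested (going by the name of the read-out)), compound 1 gives 5%, compound 3 gives 1% and compound 2 gives 1%; all three numbers lie within the scatter of one another.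

The change thiophen-2-yl in place of furan-2-yl on a saturated ring carbon gave no change at the digits printed from compound 3 to compound 2 (within the scatter). Compound 4 `CC(C)OC(=O)C1=C(C(F)(F)F)NC(=O)NC1c1cccs1` has not been measured; it arises from compound 1 by thiophen-2-yl in place of furan-2-yl on a saturated ring carbon, the same kind of change, though on the core of compound 1 the place is next to the ring atom that bears an isopropoxycarbonyl group and two ring bonds from the ring atom that bears a trifluoromethyl group, whereas on the core of compound 3 it is next to the ring atom that bears a group of 8 heavy atoms and two ring bonds from the ring atom that bears a methyl group. Since the same change gave no change at the digits printed from compound 3 to compound 2 (within the scatter), compound 4 is expected to show no change at the digits printed from compound 1 to compound 4 (within the scatter) in this assay. Compound 4 is therefore estimated at 5%, expected to fall between -5% and 15%.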

Compound 4, a percentage reported as inhibition, at one concentration (the size of the read-out at that concentration, not a potency): 7%
Compound 4: middle estimate off by 2 percentage points, on the low side; measured number inside the range.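

Thiophen-2-yl in place of furan-2-yl on a saturated ring carbon gives a number 2 percentage points higher from compound 1 to compound 4 (within the scatter) in this assay, and this step agrees with the earlier one on the other core: the same change on two cores in this assay, no change at the digits printed (within the scatter) from compound 3 to compound 2 and a number 2 percentage points higher (within the scatter) from compound 1 to compound 4, 2 percentage points apart, within the scatter of two such steps

The agreement supports carrying this change between these two cores as a step lost in the scatter, at least where inhibition at the tested concentration is this small. It does not show how the change would carry over on a core with a much larger read-out, and with both pairs so low it says little about any real difference between furan-2-yl and thiophen-2-yl.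

The compounds shown leave open what a phenyl or pyridine ring would do on the saturated ring carbon in place of these two rings. They also leave open how a carboxylic acid or an amide would read in place of the isopropoxycarbonyl group on the core of compound 1.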